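Methyl branching beside the amine in a quinolinone series

The compounds below may be only part of what the source reports. "The series", "measured", "known", "first", "only" and "open" are said of these compounds alone.

Measured so far in a toxicity assay on MDCK cells (Canis lupus familiaris) for cytotoxicity, read by crystal violet staining, with a stated time of 48 h; a higher number here means that more compound is tolerated, a lower number that less compound is tolerated:
- compound 1 `Cc1ccc2[nH]c(=O)c(CN(Cc3ccc(OC(F)F)cc3)Cc3ccc(C(C)(C)C)cc3)cc2c1`: > 5000 nM
- compound 2 `Cc1ccc2[nH]c(=O)c(CN(Cc3ccc(C(C)(C)C)cc3)C(C)c3ccc(OC(F)F)cc3)cc2c1`: > 5000 nM
- compound 3 `Cc1ccc2[nH]c(=O)c(CN(Cc3ccc(C(C)(C)C)cc3)Cc3ccc(N(C)C)c(Cl)c3)cc2c1`: > 10000 nM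

All three values are limits of this assay, not numbers. Compound 1 sits at the limit of > 5000 nM. Compound 2 sits at the same kind of limit, > 5000 nM. Compound 3 sits at a higher limit, > 10000 nM. The change methyl in place of hydrogen on a saturated chain carbon bound to an amine nitrogen and an aromatic carbon therefore gives a step that the two limits leave unreadable from compound 1 to compound 2. The cores of compound 1 and compound 3 differ by 3-chloro-4-(dimethylamino)phenyl in place of 4-(difluoromethoxy)phenyl on a saturated chain carbon bound to an amine nitrogen, and that pair gives a step that the two limits leave unreadable from compound 1 to compound 3; between compound 2 and compound 3 the step is a step that the two limits leave unreadable from compound 2 to compound 3.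

Compound 4 `Cc1ccc2[nH]c(=O)c(CN(Cc3ccc(C(C)(C)C)cc3)C(C)c3ccc(N(C)C)c(Cl)c3)cc2c1` carries the same change, (methyl in place of hydrogen on a saturated chain carbon bound to an amine nitrogen and an aromatic carbon), made on compound 3; the place is the same word for word. Since the two measured limits the limit of > 5000 nM in this assay, at which 2 of the 3 values shown sit, and the limit of > 10000 nM in this assay, at which 1 of the 3 values shown sits, leave the step unreadable, the expected step is a number no higher from compound 3 to compound 4 (the limit leaves the size open), and compound 4 is estimated at 10000 nM, between 5000 nM and 30000 nM.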

Compound 4, half-maximal cytotoxic concentration: 9800 nM
Compound 4: the middle estimate sits 1.0-fold (0.01 log units) above what was measured; the range from low to high includes it.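

In this assay compound 3 gives > 10000 nM, which is a limit of the assay and not a number. Methyl in place of hydrogen on this core gives an at least 1.0-fold lower number from compound 3 to compound 4 (0.00 log units; that floor lies within the scatter), so only a floor can be read, and it does not show that the methyl changes how much compound is tolerated. The other steps cannot be read, including the same change from compound 1 to compound 2, so nothing shows whether the change carries from one core to the other with the same size.

As far as these compounds go, what an ethyl group in place of the methyl on that saturated chain carbon would give in this assay stays open. So does the effect of that methyl on the core of compound 1 as a number.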